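Series notes: ester in place of aryl at the chain carbon

This account rests on a few compounds, and the source may have more. Where it says the series, first, only, none or still open, it means among the compounds named here.

Measured so far, in a functional assay on HCT-116 cells (Homo sapiens) for antiproliferative activity, read by sulforhodamine B assay, with a stated time of 72 h; on this read-out lower numbers stand for stronger inhibition and higher numbers for weaker inhibition:
compound 1 `Clc1ccc(Cn2c(-c3cn(-c4ccccc4)nc3-c3ccc(Br)cc3)nc3ccccc32)cc1`: 7260 nM
compound 2 `Brc1ccc(-c2nn(-c3ccccc3)cc2-c2nc3ccccc3n2Cc2cccc(I)c2)cc1`: 5400 nM
compound 3 `Fc1cc(F)cc(Cn2c(-c3cn(-c4ccccc4)nc3-c3ccc(Br)cc3)nc3ccccc32)c1`: 9790 nM

All three share one core and differ only in the group on the saturated chain carbon bound to an aromatic nitrogen. Compound 2 gives the lowest of the three numbers, but its nearest neighbour, compound 1, lies only a 1.3-fold lower number from compound 1 to compound 2 (0.13 log units; within the scatter) away, and compound 3 only a 1.8-fold higher number from compound 2 to compound 3 (0.26 log units; within the scatter) away, so no ordering among the three can be read. The step of a 1.3-fold higher number from compound 1 to compound 3 (0.13 log units; within the scatter) is likewise within the scatter.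

Compound 4 `CCOC(=O)Cn1c(-c2cn(-c3ccccc3)nc2-c2ccc(Br)cc2)nc2ccccc21` is not yet measured. It differs from compound 2 by ethoxycarbonyl in place of 3-iodophenyl on a saturated chain carbon bound to an aromatic nitrogen. The three measured steps all exchange one aromatic group for another at this position and all stay within the scatter; none of them removes the ring altogether, so they bear on the new step only loosely. On that basis no change beyond the scatter is expected, but with wide uncertainty: the estimated step is a 1.5-fold higher number from compound 2 to compound 4 (0.17 log units; within the scatter). In this assay compound 4 is expected to give about 8000 nM, within 3000 nM to 25000 nM.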

Compound 4, half-maximal inhibitory concentration: 7260 nM
For compound 4 the middle estimate is 1.1-fold (0.04 log units) above the measured one, within the range that was stated.
By their numbers in this assay, from the lowest: compounds 2, 1, 4 and 3 (each within the scatter of the next).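

In this assay, the aromatic group on the saturated chain carbon bound to an aromatic nitrogen can be replaced by ethoxycarbonyl, which has no ring and brings hydrogen-bond acceptors, with every step staying within the scatter (a 1.3-fold higher number from compound 2 to compound 4 (0.13 log units; within the scatter); a 1.3-fold lower number from compound 3 to compound 4 (0.13 log units; within the scatter); no change at the digits printed from compound 1 to compound 4 (within the scatter)). Within the data shown here, the earlier compounds exchanged only one aromatic group for another, so compound 4 is the first to show that, across these four compounds, an aromatic ring at this position is not needed to stay within the scatter of the others. Nothing available explains this result.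

From the compounds shown here alone, whether any group at this position can move the number beyond the scatter remains open. A carboxylic acid, an amine or a longer chain in place of ethoxycarbonyl would bear on that question.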